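Shortening the Chain on the Core of Compound 1

The compounds below may be only part of what the source reports. "The series", "measured", "known", "first", "only" and "open" are said of these compounds alone.

Of the compounds shown here, three have been tested in an ADME assay on MT4 cells (Homo sapiens) for cytotoxicity, read by MTT assay; on this read-out lower numbers stand for higher toxicity in this test and higher numbers for lower toxicity in this test. Compound 1 `CCCC1C(=O)N(O)C(=O)c2ccccc21` gives 25400 nM, which is the second highest of the three numbers. Compound 3 `O=c1c2ccccc2c(Cc2ccccc2)c(O)n1O` gives the highest number, 88000 nM, and compound 2 `O=C1c2ccccc2C(Cc2ccc(C(F)(F)F)cc2)C(=O)N1O` gives the lowest, 6000 nM. Compound 1 thus sits between them, and both gaps to its neighbours lie beyond the usual scatter of this assay.

Compound 4 `CCC1C(=O)N(O)C(=O)c2ccccc21` has not yet been measured. It differs from compound 1 in one place: hydrogen in place of methyl on a saturated chain carbon, two bonds along the chain from a saturated ring carbon. The rest of the shared core is unchanged.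

For the measured compounds named here, no pair among the measured compounds differs in one place only, so nothing within this set shows directly what such a change does in this assay. The chains of compound 1 and compound 4 are both short and saturated, and the account treats the change as a small one. The step expected from compound 1 to compound 4 is a 1.2-fold higher number from compound 1 to compound 4 (0.07 log units; within the scatter), which is not expected to exceed the scatter. Compound 4 is therefore estimated at 30000 nM, with a range from 12000 nM to 75000 nM.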

Compound 4, half-maximal cytotoxic concentration: 250000 nM
Compound 4: the middle estimate sits 8.3-fold (0.92 log units) below what was measured; measured number above the stated range.
By their numbers in this assay, from the lowest: compound 2; then compound 1; then compound 3; then compound 4.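

In this assay, the step from propyl to ethyl on the shared core is not a small one: hydrogen in place of methyl on a saturated chain carbon, two bonds along the chain from a saturated ring carbon, gives a large change (a 9.8-fold higher number from compound 1 to compound 4 (0.99 log units; beyond the scatter)). For the compounds shown here, this is the first pair in the set that differs in one place only, and it shows that the number at this position responds beyond the scatter to the loss of a single carbon. Nothing at hand accounts for a step of this size.

As far as these compounds go, one pair cannot show whether the number keeps moving the same way along a series of chains, so a bare methyl or a longer chain such as butyl remains open. It also leaves open how an amine or a hydroxyl at the end of this chain would read.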